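Piperidine in Place of an Open Chain: An Untested Analogue

The source may hold more compounds than are shown below. What is called first, only, known or untested is meant among the compounds shown, and "the series" means these compounds.

Of the compounds shown here, three have been measured in an assay on isolated protein for inhibition of serine/threonine-protein kinase D2 (Homo sapiens), read by mobility shift assay, tested at 30 uM; a lower number here means less inhibition, a higher number more inhibition at the concentration tested (going by the name of the read-out). Compound 1 `Nc1n[nH]c2cc(-c3cccs3)[nH]c(=O)c12` gives 5%, compound 2 `COc1cccc(-c2cc3c(c(N)nn3C)c(=O)[nH]2)c1` gives 25%, and compound 3 `COCCNc1nc(C)cc2nn(-c3ccccc3)c(N)c12` gives -1%. Compound 3 thus stands lowest of the three numbers, though its gap to compound 1 lies within the usual scatter, while its gap to compound 2 lies beyond it. Compound 4 `Cc1cc2nn(-c3ccccc3)c(N)c2c(N2CCCCC2)n1` differs from compound 3 in a single place: piperidin-1-yl in place of (2-methoxyethyl)amino on an aromatic carbon. Among the compounds with values here, no measured pair of compounds shows what such a change does in this assay, so the step of a number 6 percentage points higher from compound 3 to compound 4 (within the scatter) is expected to be small, with no direction claimed beyond the scatter. Compound 4 is therefore estimated to give 5% in this assay, within a range from -10% to 22%.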

Compound 4, a percentage reported as inhibition, at one concentration (the size of the read-out at that concentration, not a potency): 5%
Beside the measured number, compound 4's estimate shows no gap at the digits printed, within the range that was stated.
By their numbers in this assay, from the lowest: compounds 3, 1 and 4 (each within the scatter of the next); then compound 2.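

In this assay, piperidin-1-yl in place of (2-methoxyethyl)amino on the aromatic carbon next to the ring nitrogen gives a number 6 percentage points higher from compound 3 to compound 4 (within the scatter), the first step read at this position. A ring without a hydrogen-bond donor thus stands where an open chain with one stood, and the number does not move beyond the scatter. Nothing available explains this result.

On these data alone, whether a morpholine ring or an unsubstituted amine on this carbon would move the number beyond the scatter remains open. So does whether a longer chain ending in a carboxylic acid would.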